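A Second Chloro Group and Membrane Permeability

A few compounds are considered here, and "the series" means these few. Any claim that something is new, unique, unknown or untested is made for them only; others in the source may bear on it.

Three urea compounds sharing one core have been tested in an ADME assay for permeability, using PAMPA, at pH 7.4; a lower number here means that the compound crosses the layer more slowly, a higher number that the compound crosses the layer faster. Compound 2 `Cc1ccc(NC(=O)Nc2cc(C)nc3ccccc23)cc1` gives 669 10^-6 cm/s. Compound 1 `Cc1cc(NC(=O)Nc2ccc(C)c(Cl)c2)c2ccccc2n1` differs from compound 2 by chloro in place of hydrogen on an aromatic carbon, and the outcome is a 2.6-fold lower number from compound 2 to compound 1 (0.41 log units; beyond the scatter). Compound 3 `Cc1cc(NC(=O)Nc2ccc(Cl)cc2)c2ccccc2n1` differs from compound 2 by chloro in place of methyl on an aromatic carbon, giving a 1.2-fold lower number from compound 2 to compound 3 (0.10 log units; within the scatter). In this assay compound 3 gives 537 10^-6 cm/s and compound 1 gives 262 10^-6 cm/s.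

Compound 4 `Cc1cc(NC(=O)Nc2ccc(Cl)cc2Cl)c2ccccc2n1` has not yet been measured. It differs from compound 3 by chloro in place of hydrogen on an aromatic carbon. Going by the values given here, this is the same kind of change as the one separating compound 2 from compound 1, but the surroundings are not identical: in compound 1 the entering chloro group sits ortho to a methyl group and meta to a large group, while in compound 4 it sits ortho to a large group and meta to a chloro group. Because the measured pair showed a 2.6-fold lower number from compound 2 to compound 1 (0.41 log units; beyond the scatter) after this kind of change, a step in the same direction is expected, a 2.1-fold lower number from compound 3 to compound 4 (0.33 log units; beyond the scatter), with wider uncertainty since the place differs. Compound 4 is estimated to give 250 10^-6 cm/s in this assay, most likely between 130 10^-6 cm/s and 500 10^-6 cm/s.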

Compound 4, apparent permeability: 6 10^-6 cm/s
Estimate against measurement, compound 4: 42-fold (1.62 log units) above, outside the stated range (below it).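

In this assay, putting chloro in place of hydrogen on an aromatic carbon gave a 90-fold lower number from compound 3 to compound 4 (1.95 log units; beyond the scatter). The number fell in both pairs, but the size of the fall did not carry over from one core to the other: the same change on two cores in this assay, a 2.6-fold lower number (0.41 log units; beyond the scatter) from compound 2 to compound 1 and a 90-fold lower number (1.95 log units; beyond the scatter) from compound 3 to compound 4, 35-fold (1.54 log units) apart, beyond the scatter of two such steps. The direction of this change was therefore shared by these two pairs, but the size seen in one pair gave no reliable guide to the size in the other, and two pairs cannot show why the steps differ, since the entering chloro group in compound 4 sits ortho to a large group and meta to a chloro group, whereas the surroundings in compound 1 are different.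

The compounds shown leave open whether a fluoro group, a methoxy group or an amine placed ortho to a large group would lower the number as far. They also leave open whether a chloro group in that place would do so without the second chloro group meta to it.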